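The source may hold more compounds than are shown below. What is called first, only, known or untested is meant among the compounds shown, and "the series" means these compounds.

In a functional assay on OE21 cells (Homo sapiens) for cytotoxicity, read by MTT assay, with a stated time of 72 h (on this read-out lower numbers stand for stronger inhibition and higher numbers for weaker inhibition), compound 1 `COc1cc(/C=C/C=O)cc(OC)c1OC/C=C(\C)CCC=C(C)C` gives 27000 nM and compound 3 `COc1cc(/C=C/C=O)ccc1OC/C=C(\C)CCC=C(C)C` gives 34000 nM. Within the data shown here, these two values lie within the scatter of each other, and they are the only exact numbers. Compound 2 `CC(C)=CCC/C(C)=C/COc1ccc(/C=C/C(=O)O)cc1` reads > 100000 nM, which is a limit of the assay. Compound 4 `COc1cc(/C=C/CO)ccc1OC/C=C(\C)CCC=C(C)C` differs from compound 3 as follows: hydroxymethyl in place of formyl on a double-bonded chain carbon bound to a double-bonded chain carbon. Among the measured compounds shown here, the only measured step, a 1.3-fold higher number from compound 1 to compound 3 (0.10 log units; within the scatter), is hydrogen in place of methoxy on an aromatic carbon, so it leaves the formyl group untouched and does not measure this change. For the measured compounds named here, with no measured step at this place, no shift beyond the scatter is expected in this assay. The estimated step is a 1.3-fold higher number from compound 3 to compound 4 (0.12 log units; within the scatter). Compound 4 is expected at 45000 nM, with an estimated range of 18000 nM to 100000 nM.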

Compound 4, half-maximal inhibitory concentration: 23000 nM
Compound 4: middle estimate off by 2.0-fold (0.29 log units), on the high side; measured number inside the range.
By their numbers in this assay, from the lowest: compounds 4, 1 and 3 (each within the scatter of the next). At a limit, above all of these: compound 2.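

In this assay, hydroxymethyl in place of formyl gives a 1.5-fold lower number from compound 3 to compound 4 (0.17 log units; within the scatter) and so, at this place, formyl is not required for a value at this level. Among these compounds, this is the first measured step at this place, as the earlier step concerned methoxy on an aromatic carbon and left formyl untouched. No measured property on hand bears on this result.

On these data alone, how an aminomethyl or a carboxamide would read at this place stays open. Also open, as far as these compounds go, is whether the chain double bond matters, as a saturated 3-hydroxypropyl chain would show.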